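Notes on compound 4: tert-butyl amide

This account rests on a few compounds, and the source may have more. Where it says the series, first, only, none or still open, it means among the compounds named here.

Compound 1 (`CCC(=O)N[C@@H]1[C@H]2OC(C)(C)O[C@H]2O[C@@H]1[C@H](O)CO`) gives 30000000 nM in a functional assay on K562 cells (Homo sapiens) for antiproliferative activity (on this read-out lower numbers stand for stronger inhibition and higher numbers for weaker inhibition), and compound 2 (`CCCC(=O)N[C@@H]1[C@H]2OC(C)(C)O[C@H]2O[C@@H]1[C@H](O)CO`) gives 500000 nM there. Compound 3 (`CCCC(=O)N[C@H]1[C@H]2OC(C)(C)O[C@H]2O[C@@H]1[C@H](O)CO`) gives 20000000 nM in this assay and so sits within the scatter of compound 1 and far above compound 2. Compound 4 (`CC1(C)O[C@H]2O[C@H]([C@H](O)CO)[C@@H](NC(=O)C(C)(C)C)[C@H]2O1`) differs from compound 3 by tert-butyl in place of propyl on a carbonyl carbon and carries tert-butyl in place of propyl on a carbonyl carbon. Going by the values given here, two steps bear on this. Methyl on the chain gave a 60-fold lower number from compound 1 to compound 2 (1.78 log units; beyond the scatter) in the other configuration. Configuration alone gave a 40-fold higher number from compound 2 to compound 3 (1.60 log units; beyond the scatter) because of the fact that compounds 2 and 3 differ only in the configuration as drawn and no tert-butyl amide has been measured. A lower number is expected in this assay with a 4.0-fold lower number from compound 3 to compound 4 (0.60 log units; beyond the scatter) as the estimated step, well short of the chain step. The estimate for compound 4 is 5000000 nM with an expected range (500000 nM to 40000000 nM).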

Compound 4, half-maximal inhibitory concentration: 20000000 nM
The estimate for compound 4 lay 4.0-fold (0.60 log units) below the measured number, within the range that was stated.
By their numbers in this assay, from the lowest: compound 2; then compounds 3, 4 and 1 (each within the scatter of the next).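

In this assay, tert-butyl in place of propyl on a carbonyl carbon gives no change at the digits printed from compound 3 to compound 4 (within the scatter). Going by these compounds alone, this is the first change of the group on the carbonyl carbon in this configuration, and it leaves the number where it stood, whereas the chain step in the other configuration gave a 60-fold lower number from compound 1 to compound 2 (1.78 log units; beyond the scatter). Nothing at hand accounts for this flat step.

Open, from the compounds shown here alone, is whether tert-butyl in the configuration of compound 2 would keep that compound's lower number. Also open, going by these compounds, is whether a longer chain such as pentyl, or an amine on the carbonyl carbon, would move the number in either configuration.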